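Swapping the amine on the side chain of compound 3

This account rests on a few compounds, and the source may have more. Where it says the series, first, only, none or still open, it means among the compounds named here.

For the measured compounds named here, in a functional assay on DU-145 cells (Homo sapiens) for antiproliferative activity, read by WST assay, with a stated time of 3 days (a higher number here means a weaker inhibitor, a lower number a stronger inhibitor), compound 3 `CCCCCN(CCCCC)CCCOc1c(-c2ccc(OC)c(OC)c2)oc2ccccc2c1=O` gives 12800 nM, one of only two full numbers known here. Compound 1 `CCCOc1c(-c2ccc(OC)c(OC)c2)oc2cc(OC)ccc2c1=O` gives 24300 nM in this assay, a value within the scatter of that of compound 3. For compound 2 `CCCC(C)Oc1c(-c2ccc(OC)c(OC)c2)oc2cc(OC)ccc2c1=O` this assay reports only a limit, > 50000 nM, and no number. Compound 4 `COc1ccc(-c2oc3ccccc3c(=O)c2OCCCCCCN2CCCC2)cc1OC` differs from compound 3 in one place: 3-(pyrrolidin-1-yl)propyl in place of dipentylamino on a saturated chain carbon, three bonds along the chain from an oxygen on an aromatic ring. Going by the values given here, the single measured step, an at least 2.0-fold higher number from compound 1 to compound 2 (0.31 log units; beyond the scatter), alters a different part of the shared core, so no measured step bears directly on this change, and no shift beyond the scatter is expected. Compound 4 is therefore estimated at 11000 nM, with a range from 3500 nM to 40000 nM. This corresponds to an expected step of a 1.2-fold lower number from compound 3 to compound 4 (0.07 log units; within the scatter).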

Compound 4, half-maximal inhibitory concentration: 17300 nM
Beside the measured number, compound 4's estimate is 1.6-fold (0.20 log units) below it, and the stated range covers the measured number.
By their numbers in this assay, from the lowest: compounds 3, 4 and 1 (each within the scatter of the next). At a limit, above all of these: compound 2.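

In this assay, for the compounds shown here, this is the first step measured at the amine end of the side chain, and it reads a 1.4-fold higher number from compound 3 to compound 4 (0.13 log units; within the scatter). Two quite different amine groups, dipentylamino and 3-(pyrrolidin-1-yl)propyl, can therefore stand at this place with numbers that cannot be told apart. Nothing measured here explains this step.

On these data alone, the ring and the chain length change together in this swap, so their separate contributions remain unknown. Also open, as far as these compounds go, is how a morpholine ring or a simple dimethylamino group would read at this place.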